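Trimethoxybenzyl purine series: methyl on the cyclopropyl ring

The source may hold more compounds than are shown below. What is called first, only, known or untested is meant among the compounds shown, and "the series" means these compounds.

Measured so far:
compound 1, `CC[C@H](C)Cn1c(Cc2cc(OC)c(OC)c(OC)c2)nc2c(N)nc(F)nc21`: 43700 nM
compound 2, `COc1cc(Cc2nc3c(N)ncnc3n2CC2CC2)cc(OC)c1OC`: 75900 nM

In a functional assay on MCF7 cells (Homo sapiens) for antiproliferative activity (a higher number here means a weaker inhibitor, a lower number a stronger inhibitor), compound 2 gives 75900 nM and compound 1 gives 43700 nM; the two numbers lie within the scatter of each other, so neither compound can be set above the other. Compound 3, `COc1cc(Cc2nc3c(N)ncnc3n2CC2(C)CC2)cc(OC)c1OC`, differs from compound 2 only by methyl in place of hydrogen on a saturated ring carbon. Nothing measured here tells how such a change moves this assay; the weak numbers for compound 1 and compound 2 offer no lever. For compound 3 a step of no more than the scatter is expected in either direction, a 1.1-fold lower number from compound 2 to compound 3 (0.04 log units; within the scatter). Compound 3 is estimated at 70000 nM, between 30000 nM and 160000 nM.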

Compound 3, half-maximal inhibitory concentration: 112000 nM
For compound 3 the middle estimate is 1.6-fold (0.20 log units) below the measured one; the measured number falls inside the stated range.
By their numbers in this assay, from the lowest: compounds 1, 2 and 3 (each within the scatter of the next, the first and the last beyond it).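

Cyclopropylmethyl to (1-methylcyclopropyl)methyl gives, in this assay, a 1.5-fold higher number from compound 2 to compound 3 (0.17 log units; within the scatter), so this first single-place change on the saturated ring carbon does not separate the two compounds. Methyl in place of hydrogen here therefore yields no readable gain or loss. No evidence bears on this result.

On these data alone, whether a longer chain, an amine or a carboxylic acid on the same ring carbon would move the number beyond the scatter stays open. Also open, as far as these compounds go, is whether any group at this position can reach a much lower number.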